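The compounds below may be only part of what the source reports. "The series", "measured", "known", "first", "only" and "open" are said of these compounds alone.

Measured in an ADME assay on RAW264.7 cells (Mus musculus) for cytotoxicity, read by MTT assay, with a stated time of 24 h, in the absence of a further agent; on this read-out lower numbers stand for stronger inhibition and higher numbers for weaker inhibition:
- Compound 1 `CCCCOc1ccc(C(O)C2OC(=O)c3c(OC)cc(OC)cc32)cc1`: > 40000 nM
- Compound 2 `COc1cc(OC)c2c(c1)C(C(O)c1ccc(OCc3ccc(OC(F)(F)F)cc3)cc1)OC2=O`: > 40000 nM

Compound 1 gives only a limit and not a number. Compound 2 likewise stands only at a limit, > 40000 nM. Both compounds therefore sit at the limit of > 40000 nM in this assay, at which 2 of the 2 values shown sit.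

Compound 3 `COc1cc(OC)c2c(c1)C(C(O)c1ccc(OCc3ccc(OC(F)F)cc3)cc1)OC2=O` departs from compound 2 by one change, hydrogen in place of fluoro on a saturated chain carbon bound to two fluorine atoms and an oxygen on an aromatic ring: hydrogen in place of fluoro, which turns 4-(trifluoromethoxy)phenyl into 4-(difluoromethoxy)phenyl. Among the measured compounds shown here, the only measured step, a step that the two limits leave unreadable from compound 1 to compound 2, with 4-(trifluoromethoxy)phenyl in place of propyl, offers no size to carry over. In this assay no shift beyond the scatter is expected, and no direction can be assigned. The expected change is a step that the limit leaves unreadable from compound 2 to compound 3. This expectation rests on compound 2, whose limit is > 40000 nM. A report at the limit again is the likeliest outcome. The estimate for compound 3 is 50000 nM, with an expected range of 30000 nM to 100000 nM.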

Compound 3, half-maximal inhibitory concentration: > 40000 nM
Compound 3: no number, only a limit; the forecaster's own chance of this, stated with the estimate: 85%; the middle value is on the limit's open side.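

Among the compounds shown here, compound 1, compound 2 and compound 3 all stand only at a limit, so no step among them can be read: the limit of > 40000 nM in this assay, at which 3 of the 3 values shown sit.

The compounds shown leave open whether any change to the side chain would give a measurable value in this assay.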